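The source may hold more compounds than are shown below. What is called first, only, known or untested is meant among the compounds shown, and "the series" means these compounds.

Compound 3 (`O=C(N/N=C/c1ccc(Cl)c(Cl)c1)Nc1ccc(Oc2ccnc3[nH]ccc23)c(F)c1`) gives 14100 nM in a functional assay on PC-3 cells (Homo sapiens) for antiproliferative activity, read by MTT assay, with a stated time of 72 h (a higher number here means a weaker inhibitor, a lower number a stronger inhibitor), and holds the higher of the two numbers available. Compound 1 (`O=C(N/N=C/c1ccc(Br)cc1)Nc1ccc(Oc2ccnc3[nH]ccc23)c(F)c1`) gives 920 nM in this assay as well. Compound 2 (`O=C(N/N=C/c1cccc(Cl)c1Cl)Nc1ccc(Oc2ccnc3[nH]ccc23)c(F)c1`) is recorded as "not active" (no number reported) with no number to place it.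

Compound 4 (`CN(C)CCn1cccc1/C=N/NC(=O)Nc1ccc(Oc2ccnc3[nH]ccc23)c(F)c1`) is unmeasured and differs from compound 3 by one change: 1-(2-(dimethylamino)ethyl)-1H-pyrrol-2-yl in place of 3,4-dichlorophenyl on a carbon with a double bond to nitrogen.

Going by the values given here, one measured step bears on this place. It is large and beyond the scatter (a 15-fold higher number from compound 1 to compound 3 (1.19 log units; beyond the scatter)), but it only exchanges one halogenated phenyl group for another. Among the compounds with values here, no measured compound carries the incoming group, so the precedent is thin. Since compound 1 at 920 nM shows how far the number can move at this place, a sizeable step toward a lower number is expected in this assay with wide uncertainty. The expected step is a 4.7-fold lower number from compound 3 to compound 4 (0.67 log units; beyond the scatter) as an estimate. Compound 4 is estimated at 3000 nM (expected range 400 nM to 20000 nM).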

Compound 4, half-maximal inhibitory concentration: 1600 nM
Compound 4: middle estimate off by 1.9-fold (0.27 log units), on the high side, and the stated range covers the measured number.
By their numbers in this assay, from the lowest: compounds 1 and 4 (each within the scatter of the next); then compound 3.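

In this assay the place on the carbon with a double bond to nitrogen tolerates a group that is not a halogenated phenyl: 1-(2-(dimethylamino)ethyl)-1H-pyrrol-2-yl in place of 3,4-dichlorophenyl gives an 8.8-fold lower number from compound 3 to compound 4 (0.95 log units; beyond the scatter) and brings the series back to the level of the 4-bromophenyl compound. Against that group the same replacement gives a 1.7-fold higher number from compound 1 to compound 4 (0.24 log units; within the scatter), so compound 1 and compound 4 cannot be told apart in this read-out, despite sharing no ring type at this place. Nothing measured here explains either step.

Going by these compounds, it remains open whether the pyrrole ring or the 2-(dimethylamino)ethyl chain accounts for the step from the dichlorophenyl compound. An unsubstituted pyrrol-2-yl group, or a morpholine or carboxylic acid at the chain end, would separate the two.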